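Methyl in place of chloro on an aromatic carbon

This account rests on a few compounds, and the source may have more. Where it says the series, first, only, none or still open, it means among the compounds named here.

Of the compounds shown here, three have been measured so far. In a functional assay on MOLT-4 cells (Homo sapiens) (on this read-out higher numbers stand for weaker inhibition and lower numbers for stronger inhibition), compound 1 (`O=C(/C=C/c1ccc(Br)cc1)Oc1ccc(/C=C2\CCCCC2=O)cc1`) gives 180000 nM, the highest number of the three, while compound 2 (`Cc1ccc(/C=C/C(=O)Oc2ccc(/C=C3\CCCC(CN(C)C)C3=O)cc2)cc1`) gives 3390 nM, the lowest. Compound 3 (`O=C1CCCC/C1=C\c1ccc(OC(=O)c2ccc(Cl)cc2)cc1`) gives 38000 nM, the second highest number, and its gaps to both other compounds lie beyond the usual scatter.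

Compound 4 (`Cc1ccc(C(=O)Oc2ccc(/C=C3\CCCCC3=O)cc2)cc1`) has yet to be measured in this assay. It differs from compound 3 in one place: methyl in place of chloro on an aromatic carbon. This puts methyl in place of chloro on an aromatic carbon, para to a large group, turning 4-chlorophenyl into 4-methylphenyl. Among the measured compounds shown here, no measured pair shows this change or any other single change, so the data offer no direct guide to its size. The expectation therefore starts from compound 3 at 38000 nM and assumes no shift beyond the scatter. The expected change is a 1.1-fold higher number from compound 3 to compound 4 (0.04 log units; within the scatter). For compound 4, the estimated value is 42000 nM, with an expected range from 15000 nM to 120000 nM.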

Compound 4, half-maximal inhibitory concentration: 25600 nM
Beside the measured number, compound 4's estimate is 1.6-fold (0.22 log units) above it, within the range that was stated.
By their numbers in this assay, from the lowest: compound 2; then compounds 4 and 3 (each within the scatter of the next); then compound 1.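

Among the compounds shown here, this is the only pair so far that differs in one place, and in this assay it reads a 1.5-fold lower number from compound 3 to compound 4 (0.17 log units; within the scatter) for methyl in place of chloro on an aromatic carbon, para to a large group. The earlier compounds shown here could not isolate this position, and this pair shows that, on this ester, the 4-chlorophenyl and 4-methylphenyl forms cannot be told apart on this read-out. No measurement here offers an account of this result.

The compounds shown leave open whether a methoxy group, an amine or a carboxylic acid at the same ring carbon would move the number beyond the scatter. They also leave open whether methyl and chloro would stay equally close on the core of compound 2.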